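A few compounds are considered here, and "the series" means these few. Any claim that something is new, unique, unknown or untested is made for them only; others in the source may bear on it.

Compound 2 `CCN(CC)Cc1ccc(C)c(Nc2nc3ccccc3n2Cc2ccc(F)cc2)c1O` gives in an ADME assay on CHO cells (Cricetulus griseus) for inhibition, read by MTT assay (a higher number here means a weaker inhibitor, a lower number a stronger inhibitor), only a limit, > 50000 nM. Compound 1 `CCN(CC)Cc1ccc(C)c(Nc2nc3ccccc3n2Cc2ccc(C#N)cc2)c1O` likewise gives only a limit, > 50000 nM. The step that the two limits leave unreadable from compound 1 to compound 2, fluoro in place of cyano on an aromatic carbon, cannot be sized, since both values sit at the limit of > 50000 nM in this assay, at which 2 of the 2 values shown sit. Compound 3 `CCN(CC)Cc1ccc(C)c(Nc2nc3ccccc3[nH]2)c1O` differs from compound 2 by hydrogen in place of 4-fluorobenzyl on an aromatic nitrogen. No measured step touches this change, and the only step shown, a step that the two limits leave unreadable from compound 1 to compound 2, has no readable size. Compound 3 is therefore expected to stay near the limit, with an expected step of a number no higher from compound 2 to compound 3 (the limit leaves the size open). The estimate for compound 3 is 50000 nM, from 10000 nM to 200000 nM.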

Compound 3, half-maximal inhibitory concentration: > 50000 nM
Compound 3 ended at the assay's limit; the forecaster's own chance of this, stated with the estimate: 80%; the middle value lies on the limit itself.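

In this assay, among the compounds shown here, compound 3 gives > 50000 nM as a limit, and no step from compound 1 or compound 2 to compound 3 can be read. The compounds shown leave open whether any change on the shared core brings inhibition into a measurable range.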